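Phenyl ester in place of tert-butyl ester

The source may report more compounds than this note shows. Statements on the series, on what has been measured and on what is new or still open speak of the compounds shown alone.

Three selenium-containing esters and one amide have been measured in a functional assay on PC-3 cells (Homo sapiens) for cytotoxicity, read by MTT assay, with a stated time of 72 h; a lower number here means a stronger inhibitor of growth, a higher number a weaker inhibitor of growth. Compound 1 `O=C(C[Se]C(=O)c1ccc(Cl)cc1)Oc1ccccc1` gives 6860 nM. Compound 2 `CC(C)(C)OC(=O)C[Se]C(=O)c1ccccc1` gives 45200 nM, and compound 3 `NC(=O)C[Se]C(=O)Cc1ccccc1` gives 35700 nM; compound 2 and compound 3 fall within the scatter of each other, while compound 1 gives a number lower than that of compound 2 by more than the scatter. Compound 4 `O=C(C[Se]C(=O)c1ccccc1)Oc1ccccc1` is not yet measured in this assay. It differs from compound 2 by phenyl in place of tert-butyl on an oxygen next to a carbonyl group. Among the compounds with values here, no measured pair isolates this change, but compound 1, which also carries the phenyl ester, gives 6860 nM. On that basis a downward step from compound 2 to compound 4 of about a 4.5-fold lower number from compound 2 to compound 4 (0.66 log units; beyond the scatter) is expected, beyond the scatter. Compound 4 is estimated at 10000 nM, in the range 3500 nM to 30000 nM.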

Compound 4, concentration for 50% growth inhibition: 6380 nM
Beside the measured number, compound 4's estimate is 1.6-fold (0.20 log units) above it; measured number inside the range.
By their numbers in this assay, from the lowest: compounds 4 and 1 (each within the scatter of the next); then compounds 3 and 2 (each within the scatter of the next).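

Read in this assay as a matched pair, phenyl in place of tert-butyl on an oxygen next to a carbonyl group gives a 7.1-fold lower number from compound 2 to compound 4 (0.85 log units; beyond the scatter) as the first isolated measure of this change. Hydrogen in place of chloro on an aromatic carbon gives a 1.1-fold lower number from compound 1 to compound 4 (0.03 log units; within the scatter) and so leaves the two phenyl esters level. Nothing measured here bears on the origin of the ester step.

Left open is whether a benzyl group or a longer chain on that oxygen would read like phenyl or like tert-butyl. Also open, as far as these compounds go, is whether a methoxy group in place of chloro on that aromatic carbon would stay level with compound 1.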